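The compounds below may be only part of what the source reports. "The series", "measured", "known", "first", "only" and "open" are said of these compounds alone.

Compound 1, `C/C(=C\c1ccc(NC(=O)Nc2ccc(Cl)c(C(F)(F)F)c2)cc1)C(=O)N1CC(C)OC(C)C1`, in a functional assay on HT-29 cells (Homo sapiens) for inhibition, read by MTT assay, with a stated time of 120 h (on this read-out higher numbers stand for weaker inhibition and lower numbers for stronger inhibition), gives a value that is a limit of the assay, > 50000 nM.
Compound 2, `CNC(=O)/C=C(\C)c1ccc(NC(=O)Nc2ccc(Cl)c(C(F)(F)F)c2)cc1`, in this assay gives a limit as well, > 50000 nM.
Compound 3, `C/C(=C\C(=O)NC(C)c1ccccc1)c1ccc(NC(=O)Nc2ccc(Cl)c(C(F)(F)F)c2)cc1`, in this assay also gives only a limit, > 50000 nM.

Compound 2 therefore stands at the limit of > 50000 nM in this assay, at which 3 of the 3 values shown sit, and no number separates it from the other two. Compound 4, `CNC(=O)/C=C/c1ccc(NC(=O)Nc2ccc(Cl)c(C(F)(F)F)c2)cc1`, differs from compound 2 in one place: 2-(methylcarbamoyl)ethenyl in place of 1-methyl-2-(methylcarbamoyl)ethenyl on an aromatic carbon. Within the data shown here, the only measured step that touches the same arm of the shared core is the one from compound 2 to compound 3, a step that the two limits leave unreadable from compound 2 to compound 3, and since both ends of that step are limits, its size cannot be read. Among the measured compounds shown here, nothing among the measured compounds shows a change on this arm that moves the value away from the limit, so no step beyond the scatter is expected in this assay, in either direction. The expected step from compound 2 to compound 4 is a number no higher from compound 2 to compound 4 (the limit leaves the size open). Compound 4 is thus estimated at about 50000 nM, most likely reported again as a limit, with a range from 10000 nM to 200000 nM.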

Compound 4, half-maximal inhibitory concentration: 11700 nM
Compound 4: the middle estimate sits 4.3-fold (0.63 log units) above what was measured; measured number inside the range.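

In this assay the swap of 1-methyl-2-(methylcarbamoyl)ethenyl for 2-(methylcarbamoyl)ethenyl gives an at least 4.2-fold lower number from compound 2 to compound 4 (0.63 log units; beyond the scatter) on an aromatic carbon para to a large group. Among these compounds, compound 4 is the first compound here with a number rather than a limit, so this arm can move the read-out, whereas the step from compound 2 to compound 3 cannot be read. Going by these compounds, the full size of the new step stays unknown, since compound 2 gives only a limit and the step is therefore a minimum: (the limit of > 50000 nM in this assay, at which 3 of the 4 values shown sit).

Among the compounds shown here, only this one pair speaks for the change, so whether losing the methyl also lowers the number with other amides on this arm stays open. Also open, on these data alone, is what an ethyl group in place of that methyl, or a carboxylic acid in place of the methylcarbamoyl end, would do to the number.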